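Swapping an oxamide end for a pyrrole amide

This account rests on a few compounds, and the source may have more. Where it says the series, first, only, none or still open, it means among the compounds named here.

Compound 1 `NC(=O)C(=O)NCCCCCC(=O)Nc1ccccc1` was examined in a functional assay on HCT-116 cells (Homo sapiens) for inhibition, read by colorimetric assay, with a stated time of 3 days; a lower number here means a stronger inhibitor, a higher number a weaker inhibitor. For compound 1 this assay reports only a limit, > 100000 nM, not a number. Compound 3 `NC(=O)C(=O)NCCCCCCCC(=O)Nc1ccccc1` also reaches only the limit > 100000 nM in this assay. Compound 2 `O=C(CCCCCCNC(=O)C(O)(O)C(F)(F)F)Nc1ccc(-c2ccccc2)cc1`, by contrast, gives a real number in this assay, 4730 nM. Compound 1 therefore stands among the weaker entries, because two of the three values sit at the limit (the limit of > 100000 nM in this assay, at which 2 of the 3 values shown sit).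

Compound 4 `O=C(CCCCCNC(=O)c1ccc[nH]1)Nc1ccccc1` differs from compound 1 by 1H-pyrrol-2-yl in place of carbamoyl on a carbonyl carbon. Within the data shown here, no measured pair shows the effect of this change, so any guess rests on little. The step of an at least 1.6-fold lower number from compound 1 to compound 4 (0.22 log units; that floor lies within the scatter) is expected to be small, with compound 4 likely remaining weak. Compound 4 is estimated at 60000 nM, with a range from 10000 nM to 100000 nM.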

Compound 4, half-maximal inhibitory concentration: > 100000 nM
Compound 4 gave a limit, no number; the forecaster's own chance of this, stated with the estimate: 60%; at least 1.6-fold (0.22 log units) between middle value and limit.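

Among these compounds, compound 1 and compound 4 both reach only a limit in this assay, not a number, so no step between them can be read. As far as these compounds go, whether 1H-pyrrol-2-yl in place of carbamoyl changes inhibition at all stays open.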